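A Second Chloro on the Benzyl Group of Compound 1

The compounds below may be only part of what the source reports. "The series", "measured", "known", "first", "only" and "open" are said of these compounds alone.

Compound 1 `CCN(CC)Cc1ccc2nc(NC(=O)N/N=C/c3cn(Cc4ccccc4Cl)c4ccccc34)sc2c1` has been tested in a functional assay on A549 cells (Homo sapiens) for cytotoxicity, read by MTT assay, with a stated time of 72 h (a lower number here means a stronger inhibitor, a higher number a weaker inhibitor), where compound 1 gives 1390 nM. Among the three compounds measured, compound 1 stands second highest. Its nearest neighbour is compound 2 `CN(C)Cc1ccc2nc(NC(=O)N/N=C/c3cn(Cc4ccccc4Cl)c4ccccc34)sc2c1`, which in this assay gives 1080 nM; the step of a 1.3-fold lower number from compound 1 to compound 2 (0.11 log units; within the scatter) lies within the scatter. Compound 3 `CN(C)Cc1ccc2nc(NC(=O)N/N=C3\C(=O)Nc4ccc(Cl)cc43)sc2c1` is the furthest away, giving 3180 nM in this assay; it differs from compound 1 in more than one place, so only the two values can be set side by side.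

Compound 4 `CCN(CC)Cc1ccc2nc(NC(=O)N/N=C/c3cn(Cc4ccc(Cl)cc4Cl)c4ccccc34)sc2c1` is not yet measured. It differs from compound 1 by chloro in place of hydrogen on an aromatic carbon. Among the measured compounds shown here, no measured step touches this part of the shared core: the only single-place step, from compound 1 to compound 2, concerned the dimethylamino in place of diethylamino and stayed within the scatter. With nothing pointing either way, the step of a 1.1-fold lower number from compound 1 to compound 4 (0.03 log units; within the scatter) is expected to stay within the scatter. Compound 4 is estimated at 1300 nM, with a range from 500 nM to 3500 nM.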

Compound 4, half-maximal inhibitory concentration: 1900 nM
For compound 4 the middle estimate is 1.5-fold (0.16 log units) below the measured one; the range from low to high includes it.
By their numbers in this assay, from the lowest: compounds 2, 1, 4 and 3 (each within the scatter of the next, the first and the last beyond it).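

Placing a chloro on this aromatic carbon, para to a large group and meta to the existing chloro, gives the first measured single-place step on the benzyl side of the molecule, and a 1.4-fold higher number from compound 1 to compound 4 (0.14 log units; within the scatter) is what this assay records for it. The 2-chlorobenzyl and 2,4-dichlorobenzyl groups therefore cannot be told apart in this assay, so this carbon can carry a chloro without a change that can be read. No supporting measurement bears on this result, so it stays an observation without an explanation.

As far as these compounds go, whether a different group on this same carbon, such as a methoxy group, an amine or a carboxylic acid, would also stay within the scatter remains open. So does the outcome of pairing the 2,4-dichlorobenzyl group with the dimethylamino group of compound 2.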